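A few compounds are considered here, and "the series" means these few. Any claim that something is new, unique, unknown or untested is made for them only; others in the source may bear on it.

Measured so far:
- compound 1, `C[C@H](NC(=O)CN(c1nc(Cl)nc2[nH]cnc12)C1CC1)C(=O)OCc1ccccc1`: 23%
- compound 2, `NCCCC[C@H](NC(=O)CN(c1nc(Cl)nc2[nH]cnc12)C1CC1)C(=O)OCc1ccccc1`: 9.88%
- compound 3, `CC(C)C[C@H](NC(=O)CN(c1nc(Cl)nc2[nH]cnc12)C1CC1)C(=O)OCc1ccccc1`: 5.26%

In a functional assay on the whole organism (Tail, strain ICR) with Mus musculus as the target, in the tail flick test, with a stated time of 150 min, at a dose of 25 umol/kg by the oral route (on this read-out higher numbers stand for a stronger effect at the one dose given and lower numbers for a weaker effect), compound 1 gives 23%, the highest of the three numbers. The steps to the other two, a number 13.1 percentage points lower from compound 1 to compound 2 (beyond the scatter) and a number 17.7 percentage points lower from compound 1 to compound 3 (beyond the scatter), both lie beyond the scatter, while a number 4.6 percentage points lower from compound 2 to compound 3 (within the scatter) lies within it. All three of these steps concern the saturated chain carbon only. Compound 4, `C[C@H](NC(=O)CN(c1nc(Cl)nc2[nH]cnc12)C1CC1)C(=O)O`, differs from compound 1 elsewhere: hydrogen in place of benzyl on an oxygen next to a carbonyl group. Among the compounds with values here, no measured step touches this oxygen, so none bears directly on the change, and the expectation rests on the value of compound 1 alone. A modest downward step is expected, a number 8 percentage points lower from compound 1 to compound 4 (within the scatter), with a wide uncertainty. Compound 4 is therefore estimated at 15%, in a range from 0% to 35%.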

Compound 4, a percentage reported as activity, at one dose (the size of the read-out at that dose, not a potency): 14.7%
Beside the measured number, compound 4's estimate is 0.3 percentage points above it, and the stated range covers the measured number.
By their numbers in this assay, from the lowest: compounds 3, 2, 4 and 1 (each within the scatter of the next, the first and the last beyond it).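

In this assay, hydrogen in place of benzyl on this oxygen gives a number 8.3 percentage points lower from compound 1 to compound 4 (within the scatter), so the carboxy compound cannot be told apart from its benzyloxycarbonyl parent. Unlike the two changes on the saturated chain carbon that start from compound 1, this change stays within the scatter, so at this one dose the benzyl is not shown to be needed for the effect. Nothing measured here bears on the reason for this result.

On these data alone, whether a methyl or ethyl group on this oxygen would behave like benzyl or like hydrogen remains open, as does a primary amide in place of the carboxy group. As far as these compounds go, it is also open whether removing the benzyl would give a similar step from compound 2 or compound 3.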